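This account rests on a few compounds, and the source may have more. Where it says the series, first, only, none or still open, it means among the compounds named here.

Working notes on the series. In a functional assay on U-87MG ATCC cells (Homo sapiens) for cytotoxicity, read by MTT assay, with a stated time of 72 h (on this read-out lower numbers stand for stronger inhibition and higher numbers for weaker inhibition), compound 1 `CN(C)CCn1cnnc1-c1cc(Oc2ccc(NC(=O)N/N=C/c3cccc(O)c3)cc2F)ccn1` reaches only the assay limit, > 100000 nM; this is a limit and not a number (the limit of > 100000 nM in this assay, at which 1 of the 3 values shown sits). Compound 2 `CN(C)CCn1cnnc1-c1cc(Oc2ccc(NC(=O)N/N=C/c3ccc(F)cc3Cl)cc2F)ccn1` gives 1210 nM in this assay, and compound 3 `CN(C)CCn1cnnc1-c1cc(Oc2ccc(NC(=O)N/N=C/c3cc(C(C)(C)C)cc(C(C)(C)C)c3O)cc2F)ccn1` gives 520 nM. Of the two numbers shown, compound 2 has the highest; compound 3 sits beyond the scatter below it. For the measured compounds named here, the one single-point step measured, an at least 82-fold lower number from compound 1 to compound 2 (1.91 log units; beyond the scatter), is large. Compound 4 `CN(C)CCn1cnnc1-c1cc(Oc2ccc(NC(=O)N/N=C/c3cc(Br)c(O)c(Br)c3)cc2F)ccn1` is not yet measured; it differs from compound 2 by 3,5-dibromo-4-hydroxyphenyl in place of 2-chloro-4-fluorophenyl on a carbon with a double bond to nitrogen. The step from compound 1 to compound 2 bears on this change, since a hydroxyphenyl leaves and a substituted hydroxyphenyl returns, but compound 3 shows a substituted hydroxyphenyl giving 520 nM. The expected step of a 1.3-fold lower number from compound 2 to compound 4 (0.13 log units; within the scatter) is therefore small, within the scatter or slightly toward lower numbers. Compound 4 is estimated at 900 nM, in the range 200 nM to 5000 nM.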

Compound 4, half-maximal inhibitory concentration: > 100000 nM
Compound 4 ended at the assay's limit; the forecaster's own chance of this, stated with the estimate: 10%; middle value at least 110-fold (2.04 log units) away from the limit.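

In this assay, the change at the carbon with a double bond to nitrogen gives an at least 82-fold higher number from compound 2 to compound 4 (1.91 log units; beyond the scatter), so this place does not accept every substituted hydroxyphenyl. Of the hydroxyphenyl compounds shown, only compound 3 gives a readable number, 520 nM. Compound 4 stands at a limit, as compound 1 does, and the step between them cannot be read: the limit of > 100000 nM in this assay, at which 2 of the 4 values shown sit.

From the compounds shown here alone, it remains open whether the hydroxyl or the two bromine atoms account for the difference from compound 2. Going by these compounds, it also remains open how a phenyl bearing an amine or a carboxylic acid would read at this place.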